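A Chloro-for-Methyl Swap Repeated on a Second Core

The source may hold more compounds than are shown below. What is called first, only, known or untested is meant among the compounds shown, and "the series" means these compounds.

Compound 1 `Cc1ccc(NC(=S)NC(=O)c2ccc(OCc3ccc(Cl)c(Cl)c3)cc2)cc1-c1nc2ccccc2[nH]1` and compound 2 `O=C(NC(=S)Nc1ccc(Cl)c(-c2nc3ccccc3[nH]2)c1)c1ccc(OCc2ccc(Cl)c(Cl)c2)cc1` share one core, while compound 3 `Cc1ccc(NC(=O)NC(=O)c2ccc(OCc3ccccc3F)cc2)cc1-c1nc2ccccc2[nH]1` and compound 4 `O=C(NC(=O)c1ccc(OCc2ccccc2F)cc1)Nc1ccc(Cl)c(-c2nc3ccccc3[nH]2)c1` share another; the difference between the two cores is not broken down here. In a functional assay on MNK45 cells (Homo sapiens) for inhibition, read by MTT assay, with a stated time of 48 h (a lower number here means a stronger inhibitor, a higher number a weaker inhibitor), compound 1 gives 8410 nM, compound 2 gives 4600 nM, and compound 3 gives 1830 nM, the lowest of the three measured numbers. The change from compound 1 to compound 2 is chloro in place of methyl on an aromatic carbon, and it brought a 1.8-fold lower number from compound 1 to compound 2 (0.26 log units; within the scatter). Compound 4 carries the same change on the core of compound 3: chloro in place of methyl on an aromatic carbon. Among the compounds with values here, the step from compound 3 to compound 4 is expected to be a 1.7-fold lower number from compound 3 to compound 4 (0.22 log units; within the scatter), resting on the single earlier step of a 1.8-fold lower number from compound 1 to compound 2 (0.26 log units; within the scatter). Compound 4 is therefore estimated at 1100 nM in this assay, with a likely range from 450 nM to 2700 nM.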

Compound 4, half-maximal inhibitory concentration: 870 nM
Estimate against measurement, compound 4: 1.3-fold (0.10 log units) above; low and high end bracket the measured number.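

In this assay, chloro in place of methyl on an aromatic carbon brought a 2.1-fold lower number from compound 3 to compound 4 (0.32 log units; beyond the scatter). Set beside the earlier step, the change carries over to the second core at much the same size, and the two steps do not differ: the same change on two cores in this assay, a 1.8-fold lower number (0.26 log units; within the scatter) from compound 1 to compound 2 and a 2.1-fold lower number (0.32 log units; beyond the scatter) from compound 3 to compound 4, 1.2-fold (0.06 log units) apart, within the scatter of two such steps

Within the data shown here, this is agreement between only two cores, and only one of the two steps lies beyond the scatter, so it does not show that the change would carry to any other core, nor does it explain the result.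

The compounds shown leave open how a fluoro, a methoxy or an amino group would compare with chloro and methyl on the same aromatic carbon. They also leave open whether the step holds in any other assay.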